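Urea tail change on a pyrazole series in kidney cancer cells

The source may hold more compounds than are shown below. What is called first, only, known or untested is meant among the compounds shown, and "the series" means these compounds.

Compounds with measured values:
compound 1 `O=C(Nc1cccc(-n2cc(-c3ccncc3)c(-c3ccc(Cl)c(O)c3)n2)c1)Nc1ccc(Cl)c(Cl)c1` gives 7220 nM
compound 2 `COc1cc(-c2nn(-c3cccc(NC(=O)c4ccc(Cl)c(C(F)(F)F)c4)c3)cc2-c2ccncc2)ccc1Cl` gives 11000 nM
compound 3 `COc1cc(-c2nn(-c3cccc(NC(=O)Nc4ccc(Cl)c(C(F)(F)F)c4)c3)cc2-c2ccncc2)ccc1Cl` gives 1610 nM

All three were tested in a functional assay on 786-0 cells (Homo sapiens) for inhibition, read by sulforhodamine B assay, with a stated time of 48 h; on this read-out lower numbers stand for stronger inhibition of growth and higher numbers for weaker inhibition of growth. Compound 1 holds the second highest of the three numbers; its nearest neighbour is compound 2, whose value lies within the scatter, and its furthest is compound 3, which sits beyond the scatter on the lower side. Among the compounds with values here, the one step between measured compounds that differ in a single place is a 6.8-fold lower number from compound 2 to compound 3 (0.83 log units; beyond the scatter), a change at the carbonyl carbon rather than at the outer aryl ring.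

Compound 4 `O=C(Nc1cccc(-n2cc(-c3ccncc3)c(-c3ccc(Cl)c(O)c3)n2)c1)Nc1cccc(C(F)(F)F)c1` is not yet measured. It differs from compound 1 by 3-(trifluoromethyl)phenyl in place of 3,4-dichlorophenyl on an amide-type nitrogen. Within the data shown here, no measured step touches this part of the molecule, so the data offer nothing that speaks for or against a change at the outer aryl ring of the urea. Compound 3 does carry a trifluoromethyl on that ring, but it also differs from compound 1 elsewhere, so its value cannot be read as a guide. Compound 4 is therefore expected to show a step of a 1.2-fold higher number from compound 1 to compound 4 (0.10 log units; within the scatter), which is within the scatter. The estimated value of compound 4 is 9000 nM, with a range from 3000 nM to 27000 nM.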

Compound 4, concentration for 50% growth inhibition: 4690 nM
Estimate against measurement, compound 4: 1.9-fold (0.28 log units) above, and the stated range covers the measured number.
By their numbers in this assay, from the lowest: compound 3; then compounds 4, 1 and 2 (each within the scatter of the next, the first and the last beyond it).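

In this assay, within the data shown here, the exchange of 3,4-dichlorophenyl for 3-(trifluoromethyl)phenyl on the amide-type nitrogen gives a 1.5-fold lower number from compound 1 to compound 4 (0.19 log units; within the scatter) and provides the first direct reading at the outer aryl ring of the urea. This single pair does not separate the two aryl groups on this read-out, even though the entering group has 10 heavy atoms and the leaving group has 8, so this particular exchange at this position leaves growth inhibition within the usual scatter. No measurement offered here bears on why the two compounds read alike.

The compounds shown leave open whether a quite different group on this nitrogen, such as a 4-(morpholin-4-yl)phenyl, a 3-carboxyphenyl or a plain cyclohexyl, would also stay within the scatter of compound 1. They also leave open whether the carbonyl-carbon change seen in a 6.8-fold lower number from compound 2 to compound 3 (0.83 log units; beyond the scatter) would carry over to the core of compound 1, where only urea compounds are shown.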